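Two thiazole acids and a pyridine variant

The compounds below may be only part of what the source reports. "The series", "measured", "known", "first", "only" and "open" are said of these compounds alone.

Measured so far:
Compound 1, `O=C(O)Cc1sc(C(c2ccccc2)c2ccccc2)nc1-c1ccc(F)c(F)c1`, gives 43 nM.
Compound 2, `O=C(O)Cc1sc(C(c2ccc(F)cc2)c2ccc(F)cc2)nc1-c1cccc(F)c1`, gives 18 nM.

Both compounds were tested in an in vitro functional assay on HEK285-7 cells for antagonist activity at prostaglandin D2 receptor 2 (Homo sapiens), read by BRET and beta-arrestin recruitment; on this read-out lower numbers stand for stronger inhibition and higher numbers for weaker inhibition. Of the two numbers, compound 2 stands lowest; the nearest is compound 1, whose number is higher by a margin that lies beyond the usual scatter of this assay.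

Compound 3, `Nc1cc(-c2nc(C(c3ccc(F)cc3)c3ccc(F)cc3)sc2CC(=O)O)cc(F)n1`, has not yet been measured. It differs from compound 2 in one place: 2-amino-6-fluoropyridin-4-yl in place of 3-fluorophenyl on an aromatic carbon. The group that enters brings one hydrogen-bond donor and two hydrogen-bond acceptors where the group that leaves had none. For the measured compounds named here, no measured pair in this set shows the effect of such a change, so the direction cannot be read from the data. Because compound 2 already gives 18 nM, the expected step of a 1.4-fold higher number from compound 2 to compound 3 (0.14 log units; within the scatter) is taken as small and of uncertain direction, possibly within the scatter. For compound 3 the estimate in this assay is 25 nM, with a range from 7 nM to 90 nM.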

Compound 3, half-maximal inhibitory concentration: 1400 nM
For compound 3 the middle estimate is 56-fold (1.75 log units) below the measured one, outside the stated range (above it).
By their numbers in this assay, from the lowest: compound 2; then compound 1; then compound 3.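

In this assay, the position next to the ring nitrogen and next to the ring atom that bears the carboxymethyl group proves far from tolerant of this change: replacing 3-fluorophenyl with 2-amino-6-fluoropyridin-4-yl gives a 78-fold higher number from compound 2 to compound 3 (1.89 log units; beyond the scatter). For the compounds shown here, compounds 1 and 2 carry fluorinated phenyl rings at this position but differ from each other in more than one place, so this is the first step that isolates a change here, and it shows that the position can strongly affect the read-out even though the rest of compound 2 is kept. Nothing available here accounts for the size of this loss.

The entering group differs from the leaving one in its ring nitrogen, its amino group and the placing of its fluorine all at once, so the compounds shown do not tell which of these features carries the loss. From the compounds shown here alone, a pyridine ring without the amino group and an aminophenyl ring without the ring nitrogen would separate these features, and whether the same loss appears with the two unsubstituted phenyl rings of compound 1 also remains open.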